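Swapping a thiazole for a thiophene on a catechol core

This account rests on a few compounds, and the source may have more. Where it says the series, first, only, none or still open, it means among the compounds named here.

Compound 1, whose structure is `CC(=O)N1N=C(c2cc(O)c(O)c([N+](=O)[O-])c2)CC1c1nccs1`, was tested in an assay for inhibition of Catechol O-methyltransferase (Rattus norvegicus), read by fluorescence and spectrophotometry (on this read-out lower numbers stand for stronger inhibition and higher numbers for weaker inhibition), and gives 160 nM. Among the measured compounds shown here, the only other compound measured in the same way is compound 2, `N#Cc1cccc(/C=C/C(=O)c2cc(O)c(O)c([N+](=O)[O-])c2)c1`, which in this assay gives 240 nM. These two numbers lie within the usual scatter of repeated measurements of each other, so neither compound stands apart from the other on the data at hand.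

Compound 3, `CC(=O)N1N=C(c2cc(O)c(O)c([N+](=O)[O-])c2)CC1c1cccs1`, has not yet been measured. It differs from compound 1 in one place: thiophen-2-yl in place of 1,3-thiazol-2-yl on a saturated ring carbon. Both the group that leaves and the group that enters are small five-membered aromatic rings of the same heavy-atom count, and the rest of the molecule, including the catechol bearing the nitro group and the acetylated ring, is unchanged.

For the measured compounds named here, no measured pair in this set isolates this kind of swap, so there is no precedent to draw on. The change is expected to leave the number close to where compound 1 sits, with a step from compound 1 to compound 3 of a 1.3-fold higher number from compound 1 to compound 3 (0.10 log units; within the scatter), which is no more than the scatter would allow. Compound 3 is therefore estimated to give 200 nM in this assay, within a range from 70 nM to 600 nM.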

Compound 3, half-maximal inhibitory concentration: 210 nM
Estimate against measurement, compound 3: 1.1-fold (0.02 log units) below; the range from low to high includes it.
By their numbers in this assay, from the lowest: compounds 1, 3 and 2 (each within the scatter of the next).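

In this assay, the swap of 1,3-thiazol-2-yl for thiophen-2-yl on a saturated ring carbon gives a 1.3-fold higher number from compound 1 to compound 3 (0.12 log units; within the scatter). Among the compounds shown here, this is the first pair here that differs in one place, as compound 1 and compound 2 differ in much of their structure and could not speak to any single group. The swap replaces the ring nitrogen of the 1,3-thiazol-2-yl group with a carbon, and this assay does not tell the two rings apart at this position, so for this pair that ring nitrogen makes no difference beyond the usual scatter. No other data here bear on why the two rings read alike.

The compounds shown reach only two five-membered aromatic rings on this carbon, so it remains open whether a phenyl ring, a saturated ring such as cyclopentyl, a butyl chain, or a group carrying an amine or a carboxylic acid would keep the number in the same range. As far as these compounds go, it also remains open whether the same swap would read alike if the acetyl group on the neighbouring ring atom gave way to a longer acyl chain such as butanoyl.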